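Swapping a Furan for a Triazole on the Shared Core

The source may hold more compounds than are shown below. What is called first, only, known or untested is meant among the compounds shown, and "the series" means these compounds.

Compound 1 `O=C(Nc1cccc(-c2ccco2)c1)C1CCCN(C(=O)c2cc(C(F)(F)F)cc(C(F)(F)F)c2)C1`: 0%
Compound 2 `O=C(Nc1ccc(Cl)cc1)C1CCCN(C(=O)c2cccc(-c3nccs3)c2)C1`: 32%
Compound 3 `CC(=O)Nc1cccc(C(=O)N2CCCC(C(=O)Nc3ccc(Cl)cc3)C2)c1`: 4%

Of the compounds shown here, three built on the same core have been read in an ADME assay on PC-3 cells (Homo sapiens) for cytotoxicity, read by WST assay, tested at 100 uM; on this read-out lower numbers stand for less inhibition and higher numbers for more inhibition at the one concentration tested (going by the name of the read-out). Compound 1 gives 0%, and compound 3 gives 4%; these two lie within the scatter of each other, so the data set them side by side at the low end. Compound 2 gives 32%, which lies beyond the scatter above both of them. Among the measured compounds shown here, the one step between neighbours that differ in a single place is a number 28 percentage points lower from compound 2 to compound 3 (beyond the scatter).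

Compound 4 `Cn1cnnc1-c1cccc(NC(=O)C2CCCN(C(=O)c3cc(C(F)(F)F)cc(C(F)(F)F)c3)C2)c1` is the next compound, not yet measured. Relative to compound 1 the change is 4-methyl-4H-1,2,4-triazol-3-yl in place of furan-2-yl on an aromatic carbon. For the measured compounds named here, no measured pair exchanges a furan-2-yl for a 4-methyl-4H-1,2,4-triazol-3-yl, so nothing bears on this change directly; the only comparable exchange of one group on an aromatic carbon is the modest step of a number 28 percentage points lower from compound 2 to compound 3 (beyond the scatter), which moved the number down toward the floor. Compound 1 already sits at the floor, so the expectation for compound 4 in this assay is a step of a number 5 percentage points higher from compound 1 to compound 4 (within the scatter), that is no movement beyond the scatter. Compound 4 is therefore estimated at 5%, with a range from 0% to 20%.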

Compound 4, a percentage reported as inhibition, at one concentration (the size of the read-out at that concentration, not a potency): 0%
Compound 4: middle estimate off by 5 percentage points, on the high side, and the stated range covers the measured number.
By their numbers in this assay, from the lowest: compounds 1, 4 and 3 (each within the scatter of the next); then compound 2.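

In this assay the exchange of furan-2-yl for 4-methyl-4H-1,2,4-triazol-3-yl, on an aromatic carbon of a six-membered aromatic ring of carbon only and meta to a large group, gives no change at the digits printed from compound 1 to compound 4 (within the scatter) and so shows that this place on the core of compound 1 accepts a five-membered aromatic ring with more hetero atoms and more hydrogen-bond acceptors without any rise in the number beyond the scatter. The only earlier step, a number 28 percentage points lower from compound 2 to compound 3 (beyond the scatter) and on a different pair, had shown that a single exchange on an aromatic carbon can move this read-out, whereas this exchange leaves compound 4 at the bottom of the read-out with compound 1, where any further fall could not be seen. Nothing given here accounts for this flat result.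

The compounds shown leave open whether a carboxylic acid, an amine or the 1,3-thiazol-2-yl group of compound 2 at this same place would lift the number above the scatter. They also leave open whether the furan-to-triazole exchange would stay as silent on a compound that starts higher on the read-out, such as compound 2.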